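A few compounds are considered here, and "the series" means these few. Any claim that something is new, unique, unknown or untested is made for them only; others in the source may bear on it.

Compound 1 `COc1cc(Oc2ccc(NC(=O)Nc3cccc(C(F)(F)F)c3)cc2)ncn1` gives 4000 nM in an assay on isolated protein for inhibition of serine/threonine-protein kinase TNNI3K (Homo sapiens) (on this read-out higher numbers stand for weaker inhibition and lower numbers for stronger inhibition), the highest of the three numbers at hand. Compound 2 `CNc1cc(Oc2ccc(NC(=O)Nc3cccc(CF)c3)cc2)ncn1` gives 400 nM and compound 3 `CCc1cccc(NC(=O)Nc2ccc(Oc3cc(NC)ncn3)cc2)c1` gives 200 nM; both carry methylamino where compound 1 carries methoxy, yet each also differs from compound 1 at the far end, so neither pair is a single-place step. Among the compounds with values here, the only single-place step recorded, a 2.0-fold lower number from compound 2 to compound 3 (0.30 log units; within the scatter), concerns that far end and does not bear on the present change. Compound 4 `C[C@H](O)CNc1cc(Oc2ccc(NC(=O)Nc3cccc(C(F)(F)F)c3)cc2)ncn1` keeps the trifluoromethyl of compound 1 and brings ((2-hydroxypropyl)amino in place of methoxy on an aromatic carbon). Within the data shown here, no measured step covers this exchange directly. Compound 2 and compound 3, each with an amino group on the shared core, both sit lower than compound 1. For compound 4 a move toward lower numbers is therefore expected, an 8.0-fold lower number from compound 1 to compound 4 (0.90 log units; beyond the scatter). Compound 4 is estimated at 500 nM, within 150 nM to 2000 nM.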

Compound 4, half-maximal inhibitory concentration: 32 nM
Estimate against measurement, compound 4: 16-fold (1.19 log units) above, and the stated range ends above it.
By their numbers in this assay, from the lowest: compound 4; then compounds 3 and 2 (each within the scatter of the next); then compound 1.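

In this assay the exchange at the aromatic carbon next to the ring nitrogen can now be read on its own, with trifluoromethyl held constant: (2-hydroxypropyl)amino in place of methoxy gives a 130-fold lower number from compound 1 to compound 4 (2.10 log units; beyond the scatter). The position therefore accepts this longer chain, with a large gain. No measured evidence bears on the origin of that gain.

Going by these compounds, whether it rests on the amino nitrogen, the hydroxyl or the defined stereocentre stays open. The opposite stereoisomer, an unsubstituted propylamino chain and a carboxylic acid on the chain lie outside the compounds shown.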